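A Further Methoxy on a Flat Set of Values

A few compounds are considered here, and "the series" means these few. Any claim that something is new, unique, unknown or untested is made for them only; others in the source may bear on it.

compound 1 `Cc1ccc(N2CCN(C3=CC(=O)c4ccccc4C3=O)CC2)cc1` gives 8200 nM
compound 2 `COc1cccc(N2CCN(C3=CC(=O)c4ccccc4C3=O)CC2)c1` gives 15000 nM
compound 3 `COc1cc(OC)cc(N2CCN(C3=CC(=O)c4ccccc4C3=O)CC2)c1` gives 14900 nM

In a functional assay on DU-145 cells (Homo sapiens) for inhibition, read by MTT assay, with a stated time of 72 h (a lower number here means a stronger inhibitor, a higher number a weaker inhibitor), compound 3 gives 14900 nM and sits level with both compound 2 and compound 1. All three values lie within the scatter expected when a measurement of this kind is simply repeated, so no order can be drawn among them.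

The next compound is compound 4 `COc1cc(N2CCN(C3=CC(=O)c4ccccc4C3=O)CC2)cc(OC)c1OC` and it differs from compound 3 by one change, methoxy in place of hydrogen on an aromatic carbon (methoxy in place of hydrogen on an aromatic carbon, ortho to two methoxy groups and para to a large group).

Going by the values given here, the closest guide is the one measured step of the same kind, a 1.0-fold lower number from compound 2 to compound 3 (0.00 log units; within the scatter) and it showed no shift at all. The step of a 1.8-fold higher number from compound 1 to compound 2 (0.26 log units; within the scatter) is a looser guide, since it swaps 3-methoxyphenyl in place of 4-methylphenyl, and it also stayed small. With only these steps to go on, no shift beyond the scatter is expected in this assay in either direction. The expected change is a 1.1-fold lower number from compound 3 to compound 4 (0.06 log units; within the scatter) and that is too small to read as a real difference. Compound 4 is expected at 13000 nM (estimated range 6000 nM to 28000 nM).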

Compound 4, half-maximal inhibitory concentration: 11600 nM
Compound 4: middle estimate off by 1.1-fold (0.05 log units), on the high side; the range from low to high includes it.
By their numbers in this assay, from the lowest: compounds 1, 4, 3 and 2 (each within the scatter of the next).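

Going by these compounds alone, the methoxy that enters on the aromatic carbon ortho to two methoxy groups and para to a large group gives a 1.3-fold lower number from compound 3 to compound 4 (0.11 log units; within the scatter) in this assay, so this position, which carries hydrogen in the earlier compounds, takes a methoxy with no readable change in the number. Read with a 1.0-fold lower number from compound 2 to compound 3 (0.00 log units; within the scatter) as the earlier step of the same kind, this makes two methoxy additions on the six-membered aromatic ring, and neither step moves the number beyond the scatter, so the flat picture now holds across a second position and not just one. Nothing measured here explains why these values stay level, so the flatness can only be recorded as an observation.

What the compounds shown leave open is whether a group of another kind at this position, such as an amine or a carboxylic acid, would shift the number in this assay beyond the scatter. They also leave open whether a longer chain, such as ethoxy in place of this methoxy, would behave as the methoxy does.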